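The compounds below may be only part of what the source reports. "The series", "measured", "known", "first", "only" and "open" are said of these compounds alone.

Compound 1 `CCOC(=O)CCCCOc1ccc2c(=O)c(-c3ccc(O)cc3)coc2c1`: 240 nM
Compound 2 `O=c1c(-c2ccc(O)cc2)coc2cc(OCCCCCCO)ccc12`: 120 nM

Of the compounds shown here, two have so far been measured in an assay (Cricetulus griseus) for inhibition of aldehyde dehydrogenase, mitochondrial (Homo sapiens); on this read-out lower numbers stand for stronger inhibition and higher numbers for weaker inhibition. Compound 1 `CCOC(=O)CCCCOc1ccc2c(=O)c(-c3ccc(O)cc3)coc2c1` gives 240 nM, and compound 2 `O=c1c(-c2ccc(O)cc2)coc2cc(OCCCCCCO)ccc12` gives 120 nM. On these two numbers compound 2 sits alongside compound 1: the step of a 2.0-fold lower number from compound 1 to compound 2 (0.30 log units; within the scatter) shows that the two cannot be told apart on this read-out.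

Compound 3 `CCCCCCCCCCCCOc1ccc2c(=O)c(-c3ccc(O)cc3)coc2c1` has not yet been measured. It differs from compound 2 in one place: hexyl in place of hydroxy on a saturated chain carbon, six bonds along the chain from an oxygen on an aromatic ring. Among the compounds with values here, the only measured step, a 2.0-fold lower number from compound 1 to compound 2 (0.30 log units; within the scatter), also alters the far end of the chain that hangs from the oxygen on the aromatic ring, but there ethoxycarbonyl was exchanged for 2-hydroxyethyl, whereas here hydroxy leaves and hexyl enters. Neither measured compound carries a chain ending in plain carbons, so that step gives only loose guidance, and what it does show is that changing the chain end left the number within the scatter. A step of a 1.7-fold higher number from compound 2 to compound 3 (0.22 log units; within the scatter) is therefore expected, with wide uncertainty. Compound 3 is estimated at 200 nM, with a range from 60 nM to 700 nM.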

Compound 3, half-maximal inhibitory concentration: > 9000 nM
Compound 3 ended at the assay's limit; the forecaster's own chance of this, stated with the estimate: 5%; at least 45-fold (1.65 log units) between middle value and limit.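

In this assay compound 3 gives > 9000 nM, which is a limit of the assay and not a number. The chain end that changed little between ethoxycarbonyl and 2-hydroxyethyl does not accept every group: hexyl in place of hydroxy, on a saturated chain carbon six bonds along the chain from an oxygen on an aromatic ring, gives an at least 75-fold higher number from compound 2 to compound 3 (1.87 log units; beyond the scatter), and octyl in place of ethoxycarbonyl gives an at least 37-fold higher number from compound 1 to compound 3 (1.57 log units; beyond the scatter). Both steps are minimum sizes only, because the reading for compound 3 stops at the limit of the assay: the limit of > 9000 nM in this assay, at which 1 of the 3 values shown sits.

Compound 3 both loses the oxygen-bearing chain end found in compound 1 and compound 2 and carries a longer chain, so the compounds shown cannot say which of these two differences matters, or whether both do. A plain butyl chain on the same oxygen, or a chain as long as that of compound 3 but ending in an amine or a carboxylic acid, would separate length from the nature of the chain end.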